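Replacing the Methoxy Arm with a Cyclopentylpiperazine

The compounds below may be only part of what the source reports. "The series", "measured", "known", "first", "only" and "open" are said of these compounds alone.

Compound 1 `COCc1nc(Nc2ccc(C(F)(F)F)cc2)c2ccc(-c3ncccc3C(F)(F)F)cc2n1` gives the lowest number of the three measured compounds in a functional assay for antagonist activity at transient receptor potential cation channel subfamily V member 1 (Homo sapiens) (on this read-out lower numbers stand for stronger inhibition and higher numbers for weaker inhibition), with compound 1 at 1.5 nM. Compound 2 `O=P(O)(O)OCc1nc(Nc2ccc(C(F)(F)F)cc2)c2ccc(-c3ncccc3C(F)(F)F)cc2n1` gives 46 nM and compound 3 `CNCc1nc(Nc2ccc(C(F)(F)F)cc2)c2ccc(-c3ncccc3C(F)(F)F)cc2n1` gives 26 nM. Compound 4 `FC(F)(F)c1ccc(Nc2nc(CN3CCN(C4CCCC4)CC3)nc3cc(-c4ncccc4C(F)(F)F)ccc23)cc1` differs from compound 1 by 4-cyclopentylpiperazin-1-yl in place of methoxy on a saturated chain carbon bound to an aromatic carbon. Two measured steps alter the same methoxy on a saturated chain carbon bound to an aromatic carbon: a 31-fold higher number from compound 1 to compound 2 (1.49 log units; beyond the scatter) and a 17-fold higher number from compound 1 to compound 3 (1.24 log units; beyond the scatter). Both replacements raised the number strongly, and compound 4 carries a much larger group there, so a loss beyond the scatter is expected, a 17-fold higher number from compound 1 to compound 4 (1.22 log units; beyond the scatter). Compound 4 is therefore estimated at 25 nM in this assay, with a range from 6 nM to 110 nM.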

Compound 4, half-maximal inhibitory concentration: 8 nM
The estimate for compound 4 lay 3.1-fold (0.49 log units) above the measured number; the measured number falls inside the stated range.
By their numbers in this assay, from the lowest: compound 1; then compound 4; then compounds 3 and 2 (each within the scatter of the next).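

At this saturated chain carbon bound to an aromatic carbon, the much larger 4-cyclopentylpiperazin-1-yl still falls short of methoxy in this assay, with a 5.3-fold higher number from compound 1 to compound 4 (0.73 log units; beyond the scatter), yet this loss is smaller than either earlier replacement caused. The position thus accepts a group of 11 heavy atoms, with a 3.3-fold lower number from compound 3 to compound 4 (0.51 log units; beyond the scatter) and a 5.8-fold lower number from compound 2 to compound 4 (0.76 log units; beyond the scatter), so size alone does not set the order among these compounds. Nothing shown here explains why this group fares better than methylamino.

On these data alone, it remains open whether the cyclopentyl ring or the piperazine ring accounts for this gain. As far as these compounds go, it is also open whether morpholine, 4-methylpiperazine or ethoxy at this place would come closer to compound 1.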